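The source may hold more compounds than are shown below. What is called first, only, known or untested is meant among the compounds shown, and "the series" means these compounds.

Among the compounds with values here, in an ADME assay on RAW264.7 cells (Mus musculus) for cytotoxicity, read by MTT assay, with a stated time of 24 h, tested at 5 ug/mL (on this read-out lower numbers stand for a stronger effect and higher numbers for a weaker effect at the one concentration tested), compound 2 `COc1ccc(CCCc2ccc(OC)c(OC)c2OC)c(O)c1` gives 84.5%, the lowest of the two numbers measured so far, while compound 1 `COc1ccc(CCCc2ccc(OC)cc2OC)c(O)c1` gives 91.5%. Within the data shown here, the step of a number 7 percentage points lower from compound 1 to compound 2 (within the scatter) is the only measured step, and it stays within the scatter. Among the measured compounds shown here, compound 3 `COc1ccc(CCCc2cccc(OC)c2OC)c(O)c1` differs from compound 2 by hydrogen in place of methoxy on an aromatic carbon, a loss of a methoxy group that mirrors the one measured step in reverse. Since that step changed little, no shift beyond the scatter is expected, so compound 3 is estimated at 88%, between 76% and 100%, a step of a number 3.5 percentage points higher from compound 2 to compound 3 (within the scatter).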

Compound 3, a percentage reported as activity, at one concentration (the size of the read-out at that concentration, not a potency): 95.2%
For compound 3 the middle estimate is 7.2 percentage points below the measured one, and the stated range covers the measured number.
By their numbers in this assay, from the lowest: compounds 2, 1 and 3 (each within the scatter of the next, the first and the last beyond it).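

In this assay, within the data shown here, removing the methoxy para to a large group gives a number 10.7 percentage points higher from compound 2 to compound 3 (beyond the scatter) and so produces the first step beyond the scatter, though only a modest one. Here a higher number means a weaker effect, so this place responds to the change, and compound 2 keeps the stronger effect of the pair. No measurement here explains the shift. As far as these compounds go, whether an ethoxy group, a fluorine atom or a hydroxyl group at this place would give a lower or higher number remains open.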